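This account rests on a few compounds, and the source may have more. Where it says the series, first, only, none or still open, it means among the compounds named here.

Three compounds that share one core and differ only in the amine group on a saturated chain carbon bound to an aromatic carbon have been measured in a functional assay on MIA PaCa-2 cells (Homo sapiens) for inhibition, read by MTT assay, with a stated time of 48 h, tested at 10 uM; a higher number here means more inhibition of growth at the concentration tested, a lower number less inhibition of growth. Compound 1 `CCN(CC)Cc1c(O)c([C@H]2CCN(C)C[C@H]2O)c2oc(C)cc(=O)c2c1O` gives 27%, compound 2 `Cc1cc(=O)c2c(O)c(CN3CCCC3)c(O)c([C@H]3CCN(C)C[C@H]3O)c2o1` gives 28%, and compound 3 `Cc1cc(=O)c2c(O)c(CN(C(C)C)C(C)C)c(O)c([C@H]3CCN(C)C[C@H]3O)c2o1` gives 11%, the lowest of the three numbers.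

Compound 4 `Cc1cc(=O)c2c(O)c(CN3CCCC3C(=O)O)c(O)c([C@H]3CCN(C)C[C@H]3O)c2o1` has not yet been measured. It differs from compound 3 at that same place, with 2-carboxypyrrolidin-1-yl in place of diisopropylamino on a saturated chain carbon bound to an aromatic carbon.

The most relevant measured step is a number 17 percentage points lower from compound 2 to compound 3 (beyond the scatter), which here would be partly walked backwards, since the entering group contains the pyrrolidin-1-yl of compound 2. The step of a number 16 percentage points lower from compound 1 to compound 3 (beyond the scatter) is of similar size, so diisopropylamino gave the lower number against both other amines. Swapping diethylamino for pyrrolidin-1-yl gave a number 1 percentage points higher from compound 1 to compound 2 (within the scatter). Within the data shown here, no measured compound carries the carboxy part, so the data cannot say what it adds, and only a partial recovery is assumed.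

In this assay, the expected change is a number 9 percentage points higher from compound 3 to compound 4 (within the scatter). For compound 4, the estimated value is 20%, with an expected range of 5% to 35%.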

Compound 4, percent growth inhibition at one concentration: 10%
Estimate against measurement, compound 4: 10 percentage points above; the range from low to high includes it.
By their numbers in this assay, from the lowest: compounds 4 and 3 (each within the scatter of the next); then compounds 1 and 2 (each within the scatter of the next).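

In this assay the cleanest new comparison is with compound 2, where carboxy in place of hydrogen on a saturated ring carbon gives a number 18 percentage points lower from compound 2 to compound 4 (beyond the scatter) and so shows that keeping the five-membered ring of compound 2 does not by itself keep its higher number. Against the other two amines, the result reads as a number 17 percentage points lower from compound 1 to compound 4 (beyond the scatter) and a number 1 percentage points lower from compound 3 to compound 4 (within the scatter) so diisopropylamino is no longer the only group at this position that stands apart from diethylamino and pyrrolidin-1-yl, and two groups with quite different make-up now share the low end. No measured evidence on these compounds explains why either group gives this result.

The compounds shown leave open whether the low number of compound 4 belongs to the carboxylic acid itself, which a methyl ester or a primary amide on the same ring could test, and whether a piperidine or morpholine in the same place would exceed compound 2. From the compounds shown here alone, all readings come from one tested concentration, so how these amines would compare over a range of concentrations also remains unknown.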